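From pyridin-2-yl to pyridin-3-yl: a step at the limit

The compounds below may be only part of what the source reports. "The series", "measured", "known", "first", "only" and "open" are said of these compounds alone.

Measured in an ADME assay on MT4 cells (Homo sapiens) for cytotoxicity, read by XTT assay, with a stated time of 5 days; on this read-out higher numbers stand for lower toxicity in this test and lower numbers for higher toxicity in this test:
- Compound 1 `CNC(=O)[C@@H](NC(=O)[C@@](O)(CCN(Cc1ccc(Br)cc1)NC(=O)[C@@H](NC(=O)OC)C(C)(C)C)Cc1ccccc1)C(C)(C)C`: > 10000 nM
- Compound 2 `COCCNC(=O)[C@@H](NC(=O)[C@](O)(CCN(Cc1ccc(Br)cc1)NC(=O)[C@@H](NC(=O)OC)C(C)(C)C)Cc1ccccc1)C(C)C`: > 10000 nM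
- Compound 3 `CNC(=O)[C@@H](NC(=O)[C@@](O)(CCN(Cc1ccccn1)NC(=O)[C@@H](NC(=O)OC)C(C)(C)C)Cc1ccccc1)C(C)(C)C`: > 10000 nM

All three results are limits, not numbers, so compound 3 stands with the others at the limit of > 10000 nM in this assay, at which 3 of the 3 values shown sit.

Compound 4 `CNC(=O)[C@@H](NC(=O)[C@@](O)(CCN(Cc1cccnc1)NC(=O)[C@@H](NC(=O)OC)C(C)(C)C)Cc1ccccc1)C(C)(C)C` differs from compound 3 in one place: pyridin-3-yl in place of pyridin-2-yl on a saturated chain carbon bound to an amine nitrogen.

Going by the values given here, the one measured step at this place is a step that the two limits leave unreadable from compound 1 to compound 3. It offers no size to go by, so no shift beyond the scatter, in either direction, is expected in this assay. The expected step is a step that the limit leaves unreadable from compound 3 to compound 4. For compound 4 the estimate is 12000 nM, with an expected range from 6000 nM to 30000 nM, and most likely only a limit will be reported.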

Compound 4, half-maximal cytotoxic concentration: > 10000 nM
Compound 4 was reported as a limit; the forecaster's own chance of this, stated with the estimate: 90%; the middle value lies beyond the limit too.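

Compound 4 is reported only as a limit, so the steps to it from compound 3 and from compound 1 cannot be read: the limit of > 10000 nM in this assay, at which 4 of the 4 values shown sit.

From the compounds shown here alone, what concentration would actually harm these cells in this assay stays open for all four compounds.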